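This account rests on a few compounds, and the source may have more. Where it says the series, first, only, none or still open, it means among the compounds named here.

Of the compounds shown here, two with a shared core have so far been measured in a functional assay on cells (Cancer cell lines, Homo sapiens) for inhibition, read by MTT assay, with a stated time of 48 h; a lower number here means a stronger inhibitor, a higher number a weaker inhibitor. Compound 1 `COc1ccc(/C=C/C(=O)NNC(=O)c2ccc3c(c2)OCCO3)cc1` gives 930 nM in this assay, and compound 2 `O=C(/C=C/c1cccc([N+](=O)[O-])c1)NNC(=O)c1ccc2c(c1)OCCO2` gives 1560 nM. Within the data shown here, the only step recorded between them, a 1.7-fold higher number from compound 1 to compound 2 (0.22 log units; within the scatter), swaps one group for another at the same place and lies within the scatter. Compound 1 thus stands at one end of the two recorded numbers, with compound 2 at the other and no gap between them that the method can resolve.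

Compound 3 `O=C(/C=C/c1ccccc1Cl)NNC(=O)c1ccc2c(c1)OCCO2` has not yet been measured in this assay. It differs from compound 1 in a single place: 2-chlorophenyl in place of 4-methoxyphenyl on a double-bonded chain carbon bound to a double-bonded chain carbon. Among the measured compounds shown here, the one measured step that bears on this change is the exchange at the same place between compound 1 and compound 2, which stayed within the scatter. On that basis only a small step is expected, a 1.4-fold higher number from compound 1 to compound 3 (0.15 log units; within the scatter), a mild drift toward a weaker number at most. Compound 3 is therefore estimated at 1300 nM in this assay, with a range from 600 nM to 3000 nM.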

Compound 3, half-maximal inhibitory concentration: 4880 nM
Beside the measured number, compound 3's estimate is 3.8-fold (0.57 log units) below it, outside the stated range (above it).
By their numbers in this assay, from the lowest: compounds 1 and 2 (each within the scatter of the next); then compound 3.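

In this assay, the place on a double-bonded chain carbon bound to a double-bonded chain carbon now proves able to carry a change beyond the scatter, which the exchange between compound 1 and compound 2 alone could not show: 2-chlorophenyl in place of 4-methoxyphenyl gives a 5.2-fold higher number from compound 1 to compound 3 (0.72 log units; beyond the scatter) and 2-chlorophenyl in place of 3-nitrophenyl gives a 3.1-fold higher number from compound 2 to compound 3 (0.50 log units; beyond the scatter) at the same place. Both steps point the same way, so compound 3 stands apart as the weaker inhibitor from two compounds whose numbers lie within the scatter of each other, although this holds for these three groups on this one core only. Nothing available explains why 2-chlorophenyl gives the higher number here.

The compounds shown leave open whether the step belongs to the chlorine or to the 2-chlorophenyl group as a whole, a question that a plain phenyl, a 2-fluorophenyl or a 4-chlorophenyl at this place would bear on. They also leave open whether an aminophenyl or a carboxyphenyl there would stay with compound 1 and compound 2 or move as far as compound 3.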